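The compounds below may be only part of what the source reports. "The series", "measured", "known", "first", "only" and "open" are said of these compounds alone.

For the measured compounds named here, compound 3 `CC(C)(C)c1cc(NC(=O)[C@@H]2CCCCN2C(=O)C2CCS(=O)(=O)CC2)no1` gives 67 ug/mL in a physicochemical assay for solubility, read by HPLC, at pH 6.8 (a lower number here means a less soluble compound, a higher number a more soluble compound), the highest of the three numbers so far, although compound 1 `CC(C)(C)c1cc(NC(=O)[C@@H]2CCCCN2C2CC2)no1`, at 38 ug/mL, lies within the scatter of it; compound 2 `CC(C)(C)c1cc(NC(=O)[C@@H]2CCCCN2C(=O)c2ccccc2)no1` gives 0.9 ug/mL. Both measured steps were large: a 42-fold lower number from compound 1 to compound 2 (1.63 log units; beyond the scatter), and a 74-fold higher number from compound 2 to compound 3 (1.87 log units; beyond the scatter). Compound 4 `CC(C)(C)c1cc(NC(=O)[C@@H]2CCCCN2C(=O)N2CC[S+]([O-])CC2)no1` differs from compound 3 in one place: a group of 7 heavy atoms (4 carbon, 1 nitrogen, 1 oxygen, 1 sulfur; one six-membered non-aromatic ring with 2 hetero atoms) in place of a group of 8 heavy atoms (5 carbon, 2 oxygen, 1 sulfur; one six-membered non-aromatic ring with 1 hetero atom), on a carbonyl carbon. Neither measured step exchanges one saturated heterocycle for another, so neither bears closely on this change; the second step shows only that 1,1-dioxothian-4-yl in place of phenyl raised the number sharply. An exchange between two such rings on the carbonyl carbon is therefore expected to move the number little, a 1.0-fold higher number from compound 3 to compound 4 (0.02 log units; within the scatter). Compound 4 is estimated at 70 ug/mL, in the range 30 ug/mL to 160 ug/mL.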

Compound 4, solubility: 68 ug/mL
Compound 4: middle estimate off by 1.0-fold (0.01 log units), on the high side; low and high end bracket the measured number.
By their numbers in this assay, from the lowest: compound 2; then compounds 1, 3 and 4 (each within the scatter of the next).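

In this assay, the six-membered non-aromatic ring with 2 hetero atoms takes the place of 1,1-dioxothian-4-yl on the carbonyl carbon with no readable shift (a 1.0-fold higher number from compound 3 to compound 4 (0.01 log units; within the scatter)), so this position accepts a second saturated heterocycle. Set against phenyl at the same carbon, the large step recurs (a 76-fold higher number from compound 2 to compound 4 (1.88 log units; beyond the scatter)), while the step from cyclopropyl on the amine nitrogen in a ring stays within the scatter (a 1.8-fold higher number from compound 1 to compound 4 (0.25 log units; within the scatter)). No measurement given here explains these steps. The compounds shown leave open whether the sulfur matters, as a morpholine ring on the carbonyl carbon would show. They also leave open how an open alkyl chain or a carboxylic acid there would read.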